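Swapping oxygen for sulfur: compound 3 to compound 4

The compounds below may be only part of what the source reports. "The series", "measured", "known", "first", "only" and "open" are said of these compounds alone.

Measured in an ADME assay on MT4 cells (Homo sapiens) for cytotoxicity, read by MTT assay, with a stated time of 96 h; a higher number here means that more compound is tolerated, a lower number that less compound is tolerated:
- compound 1 `CC(=O)c1ccc2c(c1)nc(-c1ccc(C(F)(F)F)cc1)n2C1CCCCC1`: 41000 nM
- compound 2 `C/C(=N\NC(N)=O)c1ccc2c(c1)nc(-c1ccc(Cl)cc1)n2C1CCCCC1`: "not determined" (no result reported)
- compound 3 `C/C(=N\NC(N)=O)c1ccc2c(c1)nc(-c1ccc(C(F)(F)F)cc1)n2C1CCCCC1`: "not determined" (no result reported)

Compound 3 has no single number in this assay, and compound 2 shares that gap. For the measured compounds named here, the only number belongs to compound 1, so compound 3 cannot be ranked against anything.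

The next compound is compound 4 `C/C(=N\NC(N)=S)c1ccc2c(c1)nc(-c1ccc(C(F)(F)F)cc1)n2C1CCCCC1`. Relative to compound 3, the carbamoyl group leaves and a new group enters on an amine nitrogen: a group of 3 heavy atoms (1 carbon, 1 nitrogen, 1 sulfur; no ring) in place of a group of 3 heavy atoms (1 carbon, 1 nitrogen, 1 oxygen; no ring), on an amine nitrogen. Oxygen gives way to sulfur, and the rest of the structure stays the same.

Going by the values given here, no measured step shows what such a change does, so any expectation here is tentative. A modest move towards less compound tolerated is expected in this assay, taking compound 1 at 41000 nM as the only anchor, and the step may not go far beyond the usual scatter.

For compound 4 the half-maximal cytotoxic concentration is estimated at 15000 nM, with an expected range from 3000 nM to 60000 nM.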

Compound 4, half-maximal cytotoxic concentration: 30000 nM
Compound 4: middle estimate off by 2.0-fold (0.30 log units), on the low side; low and high end bracket the measured number.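

Compound 4 gives the series its first measured step, and it concerns the aromatic carbon rather than the amine nitrogen: in this assay the exchange of the group on that carbon gives a 1.4-fold lower number from compound 1 to compound 4 (0.14 log units; within the scatter), so the two compounds cannot be told apart here. The exchange of oxygen for sulfur on the amine nitrogen cannot be read, since compound 3 has no number to set against compound 4, and the same gap applies to compound 2. Nothing given here bears on why the numbers fall as they do.

From the compounds shown here alone, what the oxygen-bearing group itself does to the tolerated concentration remains open. So does the outcome of placing an amine or a carboxylic acid on that aromatic carbon, or a methyl group on the terminal nitrogen of the chain.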